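A Larger Ring Group on a Flat Cytotoxicity Series

The source may report more compounds than this note shows. Statements on the series, on what has been measured and on what is new or still open speak of the compounds shown alone.

Three compounds share one core and differ in the group on its carbonyl carbon. In an ADME assay on BE(2)-C cells (Homo sapiens) for cytotoxicity, read by MTT assay, with a stated time of 20 h (on this read-out higher numbers stand for lower toxicity in this test and lower numbers for higher toxicity in this test), compound 1 `CC(NC(=O)C1CCN(C(=O)c2cc3ccccc3n2Cc2ccc(Cl)cc2)CC1)c1ccncc1` gives 90100 nM. Compound 2 `CN1CCN(C(=O)C2CCN(C(=O)c3cc4ccccc4n3Cc3ccc(Cl)cc3)CC2)CC1` gives 75600 nM. Compound 3 `Cn1ccc(CNC(=O)C2CCN(C(=O)c3cc4ccccc4n3Cc3ccc(Cl)cc3)CC2)n1` gives > 100000 nM, which is a limit of the assay and not a number, so it stands at the limit of > 100000 nM in this assay, at which 1 of the 3 values shown sits.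

Compound 4 `O=C(NCC1COc2cnccc21)C1CCN(C(=O)c2cc3ccccc3n2Cc2ccc(Cl)cc2)CC1` keeps everything in compound 3 except one group, on a saturated chain carbon bound to an amide-type nitrogen: a group of 9 heavy atoms (7 carbon, 1 nitrogen, 1 oxygen; one five-membered non-aromatic ring with 1 hetero atom, one six-membered aromatic ring with 1 hetero atom) in place of a group of 6 heavy atoms (4 carbon, 2 nitrogen; one five-membered aromatic ring with 2 hetero atoms), on a saturated chain carbon bound to an amide-type nitrogen. Neither group carries a net charge.

For the measured compounds named here, no measured step makes this exact swap, so the nearest guide is how the series has behaved so far. The steps are a 1.2-fold lower number from compound 1 to compound 2 (0.08 log units; within the scatter), then an at least 1.1-fold higher number from compound 1 to compound 3 (0.04 log units; that floor lies within the scatter), and finally an at least 1.3-fold higher number from compound 2 to compound 3 (0.12 log units; that floor lies within the scatter). None of them shows a change beyond the scatter, although the two steps to compound 3 are only floors. Among these three compounds, then, changing the group has not moved the read-out, and no step beyond the scatter is expected in this assay here. The expected step is an at least 1.1-fold lower number from compound 3 to compound 4 (0.04 log units; that floor lies within the scatter). Compound 4 is estimated at 90000 nM, within an expected range of 50000 nM to 160000 nM.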

Compound 4, half-maximal cytotoxic concentration: 75800 nM
Compound 4: middle estimate off by 1.2-fold (0.07 log units), on the high side; low and high end bracket the measured number.
By their numbers in this assay, from the lowest: compounds 2, 4 and 1 (each within the scatter of the next). At a limit, above all of these: compound 3.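

In this assay, a group with two rings, one aromatic and one not, now sits on a saturated chain carbon bound to an amide-type nitrogen, whereas each earlier compound carried a single ring in its varied group. This larger group of 9 heavy atoms, with no net charge, still leaves the read-out flat against the two compounds that have real numbers, with a 1.0-fold higher number from compound 2 to compound 4 (0.00 log units; within the scatter) and a 1.2-fold lower number from compound 1 to compound 4 (0.08 log units; within the scatter). Against the 1-methyl-1H-pyrazol-3-yl group of compound 3 the comparison gives only a floor, an at least 1.3-fold lower number from compound 3 to compound 4 (0.12 log units; that floor lies within the scatter), and compound 3 stays at a limit: the limit of > 100000 nM in this assay, at which 1 of the 4 values shown sits.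

Every group shown contains a ring, so it remains open whether a carboxylic acid, a simple amine or a longer open chain in this place would move the number beyond the scatter. From the compounds shown here alone, all four compounds also share the same core, and what a change there would do to the read-out stays open too.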